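The source may report more compounds than this note shows. Statements on the series, on what has been measured and on what is new or still open speak of the compounds shown alone.

In an assay on CHO-K1 cells for displacement of a labelled ligand from adenosine receptor A1 (Homo sapiens), read by scintillation counting, with a stated time of 60 min (on this read-out higher numbers stand for weaker inhibition and lower numbers for stronger inhibition), compound 3, `N#Cc1ccccc1/C=N/Nc1nc(N)c2ncn([C@@H]3O[C@H](CO)[C@@H](O)[C@H]3O)c2n1`, gives 2.9 nM. Of the three compounds measured, compound 2, `COc1ccc(/C=N/Nc2nc(N)c3ncn([C@@H]4O[C@H](CO)[C@@H](O)[C@H]4O)c3n2)cn1`, gives 2.6 nM, and the difference a 1.1-fold higher number from compound 2 to compound 3 (0.05 log units; within the scatter) lies within the scatter, so the two cannot be told apart. Compound 1, `Nc1nc(N/N=C/c2cncs2)nc2c1ncn2[C@@H]1O[C@H](CO)[C@@H](O)[C@H]1O`, gives 22 nM, and the steps of an 8.5-fold lower number from compound 1 to compound 2 (0.93 log units; beyond the scatter) and a 7.6-fold lower number from compound 1 to compound 3 (0.88 log units; beyond the scatter) show that both six-membered aromatic replacements for 1,3-thiazol-5-yl brought modest, real gains.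

Compound 4, `CCCCc1nc(/C=N/Nc2nc(N)c3ncn([C@@H]4O[C@H](CO)[C@@H](O)[C@H]4O)c3n2)c(Cl)[nH]1`, differs from compound 3 in one place: 2-butyl-5-chloro-1H-imidazol-4-yl in place of 2-cyanophenyl on a carbon with a double bond to nitrogen. Within the data shown here, every measured step changes the same group on the carbon with a double bond to nitrogen, but none introduces a five-membered ring carrying a chain, a chlorine and a hydrogen-bond donor, so there is no close precedent. The measured steps suggest the read-out tolerates a range of aromatic groups here, with differences of modest size at most. The step of a 2.1-fold higher number from compound 3 to compound 4 (0.32 log units; beyond the scatter) is therefore expected to be small, though with wide uncertainty. Compound 4 is estimated at 6 nM, with a range from 1.5 nM to 25 nM.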

Compound 4, inhibition constant: 12 nM
Compound 4: middle estimate off by 2.0-fold (0.30 log units), on the low side; measured number inside the range.
By their numbers in this assay, from the lowest: compounds 2 and 3 (each within the scatter of the next); then compounds 4 and 1 (each within the scatter of the next).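

The carbon with a double bond to nitrogen also accepts a larger five-membered aromatic ring carrying a butyl chain and a chlorine, but in this assay 2-butyl-5-chloro-1H-imidazol-4-yl falls modestly short of both six-membered groups, with a 4.1-fold higher number from compound 3 to compound 4 (0.62 log units; beyond the scatter) and a 4.6-fold higher number from compound 2 to compound 4 (0.66 log units; beyond the scatter). Against 1,3-thiazol-5-yl, the only other five-membered ring here, the step is a 1.8-fold lower number from compound 1 to compound 4 (0.26 log units; within the scatter), so these two cannot be told apart, and across all four compounds the six-membered rings give the lower numbers, with no compound going against this. No measurement shown here explains these differences.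

From the compounds shown here alone, the butyl chain, the chlorine and the ring all arrive in one change, so their separate contributions remain unknown. Going by these compounds, it also remains open how the number would respond to a methyl group or an amine in place of the butyl chain, or to hydrogen in place of the chlorine.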